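Aryl variation on the thiadiazole of a bromofuranone series

The source may hold more compounds than are shown below. What is called first, only, known or untested is meant among the compounds shown, and "the series" means these compounds.

Measured so far:
- Compound 1, `CC1CCC(C(C)C)C(O[C@H]2OC(=O)C(Br)=C2Sc2nnc(-c3ccc(Cl)cc3)s2)C1`: 2200 nM
- Compound 2, `CC1CCC(C(C)C)C(O[C@H]2OC(=O)C(Br)=C2Sc2nnc(-c3ccco3)s2)C1`: 1700 nM

In a functional assay on HeLa cells (Homo sapiens) for antiproliferative activity, read by MTT assay, with a stated time of 24 h (on this read-out lower numbers stand for stronger inhibition and higher numbers for weaker inhibition), compound 1 gives 2200 nM. Of the two numbers in hand, compound 1 stands alongside compound 2, the gap being a 1.3-fold lower number from compound 1 to compound 2 (0.11 log units; within the scatter), so no order between the two can be read.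

The next compound, compound 3, `CC1CCC(C(C)C)C(O[C@H]2OC(=O)C(Br)=C2Sc2nnc(-c3cccnc3)s2)C1`, differs from compound 1 in one place: pyridin-3-yl in place of 4-chlorophenyl on an aromatic carbon. Within the data shown here, the only step that bears on this change is the one from compound 1 to compound 2, a 1.3-fold lower number from compound 1 to compound 2 (0.11 log units; within the scatter), in which a different aromatic group took the same position on the shared core without moving the number beyond the scatter. Nothing measured here separates one aromatic replacement from another at that position.

On that basis the change to pyridin-3-yl is expected to give, in this assay, a 1.1-fold lower number from compound 1 to compound 3 (0.04 log units; within the scatter), a step not beyond the scatter. Compound 3 is therefore estimated at 2000 nM, with a range from 900 nM to 4500 nM.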

Compound 3, half-maximal inhibitory concentration: 5600 nM
Beside the measured number, compound 3's estimate is 2.8-fold (0.45 log units) below it; the whole stated range lies below it.
By their numbers in this assay, from the lowest: compounds 2 and 1 (each within the scatter of the next); then compound 3.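

Working notes: in this assay this aromatic carbon is not indifferent to the aromatic group it carries, since a 2.5-fold higher number from compound 1 to compound 3 (0.41 log units; beyond the scatter) and a 3.3-fold higher number from compound 2 to compound 3 (0.52 log units; beyond the scatter) both lie beyond the scatter, a separation that the earlier pair did not give. Ring size alone does not order the three groups: 4-chlorophenyl and pyridin-3-yl both bring a six-membered aromatic ring yet part from each other, while 4-chlorophenyl and furan-2-yl stay within the scatter of each other. No measurement at hand explains the shift, and its size is modest in both steps.

Still open, going by these compounds, is whether the shift follows the ring nitrogen itself or its place in the ring, a question that pyridin-2-yl and pyridin-4-yl would address, and whether the chlorine of compound 1 contributes anything, which plain phenyl would show. Also open, on these data alone, is how this position responds to groups of another kind, such as an aminophenyl or a carboxyphenyl group, or a saturated ring such as cyclohexyl.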